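Aryl swap on the fused core of compound 1

This account rests on a few compounds, and the source may have more. Where it says the series, first, only, none or still open, it means among the compounds named here.

Compound 1 `CC#C[C@@H](Cc1nnn[nH]1)c1ccc(OCc2ccc3scc(-c4ccccc4C(F)(F)F)c3c2)cc1` gives 2 nM in a functional assay on cells for agonist activity at Free fatty acid receptor 1 (Rattus norvegicus), read by FLIPR and calcium flux (a lower number here means that less compound is needed, a higher number that more compound is needed for the effect), the lowest of the three numbers at hand. Compound 3 `CC#C[C@@H](Cc1nnn[nH]1)c1ccc(OCc2ccc3sc(C#N)c(-c4ccccc4C)c3c2)cc1` gives 19 nM in this assay, and compound 2 `CC#C[C@@H](Cc1nnn[nH]1)c1ccc(OCc2cc(F)c3scc(-c4ccc(OC)cc4C)c3c2)cc1` gives 39 nM; both gaps from compound 1 lie beyond the scatter, so compound 1 is the most potent of the three. Within the data shown here, no two measured compounds differ in only one place, so no single step has been isolated. Compound 4 `CC#C[C@@H](Cc1nnn[nH]1)c1ccc(OCc2ccc3scc(-c4cccnc4C)c3c2)cc1` has not yet been measured; it differs from compound 1 thus: 2-methylpyridin-3-yl in place of 2-(trifluoromethyl)phenyl on an aromatic carbon. Because compound 2 at 39 nM and compound 3 at 19 nM both sit well above compound 1, a loss beyond the scatter is expected from compound 1 to compound 4, a 7.5-fold higher number from compound 1 to compound 4 (0.88 log units; beyond the scatter). Compound 4 is estimated at 15 nM, within a range of 4 nM to 60 nM.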

Compound 4, half-maximal effective concentration: 20 nM
Estimate against measurement, compound 4: 1.3-fold (0.12 log units) below; measured number inside the range.
By their numbers in this assay, from the lowest: compound 1; then compounds 3, 4 and 2 (each within the scatter of the next, the first and the last beyond it).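

Among these compounds, at this aromatic carbon, two ring bonds from the ring sulfur, the first single-place comparison gives a 10-fold higher number from compound 1 to compound 4 (1.00 log units; beyond the scatter) in this assay when 2-methylpyridin-3-yl replaces 2-(trifluoromethyl)phenyl. The aryl group at this position thus moves the number on an otherwise unchanged core, which compound 2 and compound 3, each differing from compound 1 in more than one place, could not show. Nothing on hand explains this step. From the compounds shown here alone, it remains open whether the ring nitrogen or the exchange of trifluoromethyl for methyl carries the step; 2-(trifluoromethyl)pyridin-3-yl on the same core would separate the two.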